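The compounds below may be only part of what the source reports. "The series", "measured", "known", "first", "only" and "open" are said of these compounds alone.

Compound 1 `COc1cc(-c2nn(-c3cccc(NC(=O)Nc4cc(C(F)(F)F)cc(C(F)(F)F)c4)c3)cc2-c2ccncc2)ccc1Cl` and compound 2 `O=C(Nc1cccc(-n2cc(-c3ccncc3)c(-c3ccc(Cl)c(O)c3)n2)c1)Nc1cc(C(F)(F)F)cc(C(F)(F)F)c1` are built on one shared core and differ in a single spot: compound 2 carries hydrogen in place of methyl on an oxygen on an aromatic ring. In a functional assay on HOP-92 cells (Homo sapiens) for inhibition, read by sulforhodamine B assay, with a stated time of 48 h (a higher number here means a weaker inhibitor of growth, a lower number a stronger inhibitor of growth), compound 1 gives 1150 nM, and compound 2 gives 1750 nM. That exchange produced a 1.5-fold higher number from compound 1 to compound 2 (0.18 log units; within the scatter). Compound 3 `COc1cc(-c2nn(-c3cccc(NC(=O)Nc4ccc(Cl)c(C(F)(F)F)c4)c3)cc2-c2ccncc2)ccc1Cl` differs from compound 1 elsewhere in the molecule, and the difference between the core of compound 1 and the core of compound 3 is not broken down here. In this assay compound 3 gives 1480 nM, a number close to both earlier ones. Among the compounds with values here, compound 4 `O=C(Nc1cccc(-n2cc(-c3ccncc3)c(-c3ccc(Cl)c(O)c3)n2)c1)Nc1ccc(Cl)c(C(F)(F)F)c1` has not yet been measured; it is made from compound 3 by hydrogen in place of methyl on an oxygen on an aromatic ring, which is the same change, at the same place, as the one separating compound 1 from compound 2. Because the measured pair showed a 1.5-fold higher number from compound 1 to compound 2 (0.18 log units; within the scatter), a step of similar size is expected from compound 3 to compound 4, namely a 1.4-fold higher number from compound 3 to compound 4 (0.15 log units; within the scatter). The estimated result for compound 4 in this assay is therefore 2100 nM, with a likely range from 1000 nM to 4500 nM.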

Compound 4, concentration for total growth inhibition: 1460 nM
The estimate for compound 4 lay 1.4-fold (0.16 log units) above the measured number, and the stated range covers the measured number.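

Replacing the methoxy with a hydroxy on the core of compound 3 gives a 1.0-fold lower number from compound 3 to compound 4 (0.01 log units; within the scatter) in this assay. Set beside the earlier case, the same change gives results on the two cores that cannot be told apart: the same change on two cores in this assay, a 1.5-fold higher number (0.18 log units; within the scatter) from compound 1 to compound 2 and a 1.0-fold lower number (0.01 log units; within the scatter) from compound 3 to compound 4, 1.5-fold (0.19 log units) apart, within the scatter of two such steps. So in both pairs, going from 4-chloro-3-methoxyphenyl to 4-chloro-3-hydroxyphenyl leaves the number within the scatter, but this rests on only two cores and does not establish a rule for the whole series, nor does it show a shift in either direction that carries from one core to another.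

The compounds shown hold only a methoxy or a hydroxy on this ring, so it remains open whether an amine, a carboxylic acid or a longer chain such as propoxy in the same place would leave the number just as unmoved. On these data alone, it also remains open whether the two cores would still match for a group that, unlike these, moves the number beyond the scatter on at least one of them.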